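The source may report more compounds than this note shows. Statements on the series, on what has been measured and on what is new or still open speak of the compounds shown alone.

Measured compounds:
compound 1 `O=C1/C(=N\NC(=S)NO)c2cc(Cl)ccc2N1CN1CCN(c2ccccc2)CC1` gives 273000 nM
compound 2 `CONC(=S)N/N=C1\C(=O)N(CN2CCN(c3ccccc3)CC2)c2ccc(Cl)cc21` gives 267000 nM
compound 3 `COc1ccc(N2CCN(CN3C(=O)/C(=N\NC(=S)NO)c4cc(C)ccc43)CC2)cc1` gives 321000 nM

All three numbers come from an ADME assay on MT4 cells (Homo sapiens) for cytotoxicity, read by spectrophotometry, with a stated time of 5 days; on this read-out lower numbers stand for higher toxicity in this test and higher numbers for lower toxicity in this test. Compound 2 has the lowest of the three numbers, but its gaps to compound 1 and to compound 3 both lie within the scatter, so the three compounds cannot be told apart on this read-out. Among the compounds with values here, the only single-point step measured so far, a 1.0-fold lower number from compound 1 to compound 2 (0.01 log units; within the scatter), changed the number by nothing beyond the scatter.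

Compound 4 `CONC(=S)N/N=C1\C(=O)N(CN2CCN(c3ccc(Cl)cc3)CC2)c2ccc(Cl)cc21` differs from compound 2 in one place: chloro in place of hydrogen on an aromatic carbon. Cut one bond further out, the change reads phenyl to 4-chlorophenyl. Within the data shown here, no measured step in this set involves this kind of change; the one step available concerns a methyl in place of hydrogen on an oxygen, a different part of the molecule, and it stayed flat. Compound 3 differs from compound 2 in several places and also lands within the scatter of compound 2, so nothing in the data points in either direction. The step of a 1.0-fold higher number from compound 2 to compound 4 (0.00 log units; within the scatter) is therefore expected to stay within the scatter. Compound 4 is estimated at 270000 nM, with a range from 135000 nM to 540000 nM.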

Compound 4, half-maximal cytotoxic concentration: 229000 nM
For compound 4 the middle estimate is 1.2-fold (0.07 log units) above the measured one; low and high end bracket the measured number.
By their numbers in this assay, from the lowest: compounds 4, 2, 1 and 3 (each within the scatter of the next).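

Replacing phenyl with 4-chlorophenyl probes a part of the molecule that the earlier single-place step, on an oxygen, did not touch. In this assay, this change gives a 1.2-fold lower number from compound 2 to compound 4 (0.07 log units; within the scatter), so adding chloro on this aromatic carbon, para to a large group, produces no difference that can be told from the usual scatter of repeated measurements. No available measurement offers an explanation for this result.

On these data alone, whether an amine or a carboxylic acid on the same aromatic carbon would shift the number beyond the scatter remains open. Also open, as far as these compounds go, is whether chloro at this place would give the same flat result with hydrogen instead of methyl on the oxygen, as in compound 1.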